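A few compounds are considered here, and "the series" means these few. Any claim that something is new, unique, unknown or untested is made for them only; others in the source may bear on it.

Measured compounds and their values:

compound 1 `CN(Cc1ccccc1F)C(=O)CNC(=O)c1ccc(S(C)(=O)=O)c([N+](=O)[O-])c1` — 11400 nM
compound 2 `CN(CC(=O)N1CCN(c2ccc(F)cc2)CC1)C(=O)c1ccc(S(C)(=O)=O)c([N+](=O)[O-])c1` — 17200 nM
compound 3 `CN(Cc1ccccc1)C(=O)CNC(=O)c1ccc(S(C)(=O)=O)c([N+](=O)[O-])c1` — > 27000 nM

In an ADME assay on HepG2 cells (Homo sapiens) for cytotoxicity, read by CellTiter-Glo and ATP content, with a stated time of 72 h (on this read-out lower numbers stand for an effect already at smaller amounts and higher numbers for an effect only at larger amounts of compound), compound 1 gives 11400 nM. Compound 2 gives 17200 nM, and the two values sit within the scatter of each other. For compound 3 the assay reports only a limit, > 27000 nM, and not a number. This is the limit of > 27000 nM in this assay, at which 1 of the 3 values shown sits.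

The change from compound 1 to compound 3 is hydrogen in place of fluoro on an aromatic carbon; the step it made is an at least 2.3-fold higher number from compound 1 to compound 3 (0.37 log units; beyond the scatter). How the core of compound 1 and the core of compound 2 differ is not broken down here.

Compound 4 `CN(CC(=O)N1CCN(c2ccccc2)CC1)C(=O)c1ccc(S(C)(=O)=O)c([N+](=O)[O-])c1` has not yet been measured in this assay. It differs from compound 2 by hydrogen in place of fluoro on an aromatic carbon. Among the measured compounds shown here, this is the same kind of change as the one from compound 1 to compound 3, though the place is not identical: in compound 1 the fluoro sits ortho to a large group, in compound 2 para to a large group.

Resting on the step of an at least 2.3-fold higher number from compound 1 to compound 3 (0.37 log units; beyond the scatter) from compound 1 to compound 3, a step of similar direction, a 1.7-fold higher number from compound 2 to compound 4 (0.24 log units; within the scatter), is expected here. For compound 4 the estimated value in this assay is 30000 nM, expected to fall between 14000 nM and 60000 nM, with a fair chance that only a limit is reported.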

Compound 4, half-maximal effective concentration: > 27000 nM
Compound 4: no number, only a limit; the forecaster's own chance of this, stated with the estimate: 50%; the middle value does not contradict the limit.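

In this assay compound 4 returns only a limit, > 27000 nM, and not a number. Read as a floor, the change from 4-fluorophenyl to phenyl gives an at least 1.5-fold higher number from compound 2 to compound 4 (0.19 log units; that floor lies within the scatter), so the direction seen on the core of compound 1 is not contradicted on this second core, although this floor alone does not establish a real step there. The result therefore supports carrying the direction of the change across the two cores only loosely, and it does not show that the size of the change carries over: the same change on two cores in this assay, an at least 2.3-fold higher number (0.37 log units; beyond the scatter) from compound 1 to compound 3 and an at least 1.5-fold higher number (0.19 log units; that floor lies within the scatter) from compound 2 to compound 4; the limit leaves it open whether they differ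

The compounds shown leave open how far the values of compound 3 and compound 4 would lie from the limit of this assay, and so whether removing the fluoro does more on one core than on the other. They also leave open how a chloro, methyl or methoxy group at the place of the fluoro would read in this assay, and what would follow if an amine or a carboxylic acid took the place of the nitro group on the shared benzoyl part.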